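This account rests on a few compounds, and the source may have more. Where it says the series, first, only, none or still open, it means among the compounds named here.

Going by the values given here, in a functional assay (aorta) with Rattus norvegicus as the target (a higher number here means that more compound is needed for the effect, a lower number that less compound is needed), only two compounds have been measured so far. Compound 1 (`CC(C)NC1=NS(=O)(=O)c2cc(F)ccc2N1`) gives 43.1 uM, while compound 2 (`CCCNC1=NS(=O)(=O)c2cc(Br)ccc2N1`) gives 5.9 uM. Compound 2 therefore holds the lower of the two numbers, and the gap between them lies beyond the scatter of repeated measurements. Compound 3 (`CC(C)NC1=NS(=O)(=O)c2cc(Br)ccc2N1`) has yet to be measured. It has isopropyl in place of propyl on an amine nitrogen relative to compound 2, with the same atoms joined differently: isopropyl in place of propyl on an amine nitrogen. Among the compounds with values here, no measured pair shows this change on its own, so the expectation rests only on the small size of the change and on the value of compound 2. The expected move is a 1.4-fold higher number from compound 2 to compound 3 (0.13 log units; within the scatter), a slight rise in the number that stays within the scatter. For compound 3 the estimated value in this assay is 8 uM, with an expected range of 3 uM to 22 uM.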

Compound 3, concentration for half-maximal effect: 4.8 uM
Compound 3: the middle estimate sits 1.7-fold (0.22 log units) above what was measured; measured number inside the range.
By their numbers in this assay, from the lowest: compounds 3 and 2 (each within the scatter of the next); then compound 1.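

In this assay, isopropyl in place of propyl on an amine nitrogen gives a 1.2-fold lower number from compound 2 to compound 3 (0.09 log units; within the scatter), a step within the scatter, so the two chains cannot be told apart at this nitrogen in the bromo series. Compound 3 also isolates the change on the aromatic carbon: bromo in place of fluoro gives a 9.0-fold lower number from compound 1 to compound 3 (0.95 log units; beyond the scatter), and of the two single changes now shown, only this one lies beyond the scatter. No measurement shown here explains the size of either step.

The compounds shown leave open where chloro or iodo, or a methoxy group, would fall on that aromatic carbon. They also leave open how a longer chain such as butyl, or a ring such as cyclopentyl, would read on the amine nitrogen.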